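The source may hold more compounds than are shown below. What is called first, only, known or untested is meant among the compounds shown, and "the series" means these compounds.

Compound 1 `CCOc1ccccc1-c1ccc(-c2nc3cnccc3c(NC(COC)C(N)=O)c2C#N)cc1`: 2.8 in a physicochemical assay for lipophilicity, read by HPLC, at pH 7.5; on this read-out higher numbers stand for higher lipophilicity and lower numbers for lower lipophilicity
Compound 2 `CC(Nc1c(C#N)c(-c2ccc(Br)cc2)nc2cnccc12)C(N)=O`: 2.1
Compound 3 `CC[C@@H](Nc1c(C#N)c(-c2ccc(-c3ccccc3CO)cc2)nc2cnccc12)C(N)=O`: 2.1

Compound 3 stands level with compound 2 at the digits shown, and the two together are the lowest of the three numbers in this assay; compound 1 sits a clearly higher step away, beyond the scatter. The step to the unmeasured compound 4 `CC[C@@H](Nc1c(C#N)c(-c2ccc(-c3ccc(F)cc3)cc2)nc2cnccc12)C(N)=O` is a single change on the same core: 4-fluorophenyl in place of 2-(hydroxymethyl)phenyl on an aromatic carbon. The group that leaves carries one hydrogen-bond donor and one acceptor, the group that enters carries none, so the step is expected to move the number upward, by more than the scatter, with an estimated step of a number 1.00 log units higher from compound 3 to compound 4 (beyond the scatter). Compound 4 is therefore expected to give about 3.1, in a range from 2.6 to 3.6.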

Compound 4, distribution coefficient: 2.7
Beside the measured number, compound 4's estimate is 0.40 log units above it, and the stated range covers the measured number.
By their numbers in this assay, from the lowest: compounds 2 and 3 (each within the scatter of the next); then compounds 4 and 1 (each within the scatter of the next).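

Only compound 3 and compound 4 differ in one place, and on this aromatic carbon, para to a large group, putting 4-fluorophenyl in place of 2-(hydroxymethyl)phenyl gives in this assay a number 0.60 log units higher from compound 3 to compound 4 (beyond the scatter). The hydroxymethyl group leaves and the fluorine enters in the same step, so this pair cannot apportion the shift between them. Nothing measured here explains the step.

The compounds shown leave open how a plain phenyl, which carries neither group, would read at this position. They also leave open how a phenyl bearing an aminomethyl group or a carboxylic acid would read there.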